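The compounds below may be only part of what the source reports. "The series", "measured", "known", "first", "only" and "open" are said of these compounds alone.

Compound 1 `O=C(N/N=C\c1cccc(O)c1)Nc1nnc(COc2ccc3ccccc3c2)o1` gives 300 mg/kg in a functional assay on the whole organism (strain Swiss albino) with Mus musculus as the target, in the maximal electroshock model, with a stated time of 4 h; on this read-out higher numbers stand for an effect only at larger amounts of compound and lower numbers for an effect already at smaller amounts. Compound 2 `O=C(NN=C(c1ccccc1)c1ccccc1)Nc1nnc(COc2ccc3ccccc3c2)o1` gives 300 mg/kg and compound 3 `O=C(N/N=C(/c1ccccc1)c1ccc(O)cc1)Nc1nnc(COc2ccc3ccccc3c2)o1` gives 300 mg/kg, so compound 1 stands level with both at the digits shown, within the scatter. Going by the values given here, the single measured step, no change at the digits printed from compound 2 to compound 3 (within the scatter), is flat. Compound 4 `C/C(=N/NC(=O)Nc1nnc(COc2ccc3ccccc3c2)o1)c1ccc(N)cc1` differs from compound 1 as follows: a group of 10 heavy atoms (8 carbon, 2 nitrogen; one six-membered aromatic ring of carbon only) in place of a group of 9 heavy atoms (7 carbon, 1 nitrogen, 1 oxygen; one six-membered aromatic ring of carbon only), on an amide-type nitrogen. Among the compounds with values here, no measured step touches the group on this amide-type nitrogen; the only comparison to hand, hydroxy in place of hydrogen on an aromatic carbon from compound 2 to compound 3, did not move the read-out, and all three measured compounds sit at one value. On that basis the step of no change at the digits printed from compound 1 to compound 4 (within the scatter) is expected to stay within the scatter. Compound 4 is therefore estimated at 300 mg/kg, with a range from 100 mg/kg to 600 mg/kg.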

Compound 4, minimum effective dose: 300 mg/kg
Compound 4: middle estimate and measured number agree at the digits printed; the measured number falls inside the stated range.
By their numbers in this assay, from the lowest: compounds 1, 2, 3 and 4 (each within the scatter of the next).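

Going by these compounds alone, the step of no change at the digits printed from compound 1 to compound 4 (within the scatter) in this assay is the first reading on the group carried on the amide-type nitrogen, where the earlier step covered only hydroxy in place of hydrogen on an aromatic carbon. Exchanging the whole group of 9 heavy atoms for the group of 10 heavy atoms leaves the read-out within the scatter, so this position tolerates more than a single-atom edit in this series. No supporting evidence bears on this result.

With all compounds shown at one level, no change at this position has yet separated any two of them. Going by these compounds, whether a carboxylic acid or a nitrile in this group would move the read-out remains open.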